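The compounds below may be only part of what the source reports. "The series", "measured", "known", "first", "only" and "open" are said of these compounds alone.

Measured compounds:
- Compound 1, `O=C(/C=C/c1ccc(C(F)(F)F)cc1)Nc1nnc(-c2ccc(Cl)cc2)s1`, gives 3.09 ug/mL in a functional assay on A549 cells (Homo sapiens) for antiproliferative activity, read by MTT assay, with a stated time of 48 h; on this read-out lower numbers stand for stronger inhibition and higher numbers for weaker inhibition.
- Compound 2, `O=C(/C=C/c1ccc(F)cc1)Nc1nnc(-c2ccccc2)s1`, gives 1.82 ug/mL in this assay.

Compound 2 holds the lowest of the two numbers in this assay, but its nearest neighbour, compound 1, sits within the scatter of it, so the two compounds cannot be ranked against each other on these data. Compound 1 and compound 2 differ in two places at once, so nothing can be said about either change on its own from this pair.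

Compound 3, `O=C(/C=C/c1ccc(C(F)(F)F)cc1)Nc1nnc(-c2ccccc2)s1`, has not yet been measured in this assay. It differs from compound 2 in one place: trifluoromethyl in place of fluoro on an aromatic carbon. Among the measured compounds shown here, the group that enters is the one already present in compound 1, whose value in this assay lies within the scatter of compound 2, which gives no ground to expect a large move in either direction. The step expected in this assay is a 1.4-fold higher number from compound 2 to compound 3 (0.14 log units; within the scatter), which is no step beyond the scatter. For compound 3 the estimate in this assay is 2.5 ug/mL, with a range from 1 ug/mL to 6.5 ug/mL.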

Compound 3, half-maximal inhibitory concentration: 1.78 ug/mL
The estimate for compound 3 lay 1.4-fold (0.15 log units) above the measured number, within the range that was stated.
By their numbers in this assay, from the lowest: compounds 3, 2 and 1 (each within the scatter of the next).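

With trifluoromethyl in place of fluoro on an aromatic carbon, para to a large group, this assay gives a 1.0-fold lower number from compound 2 to compound 3 (0.01 log units; within the scatter), so the read-out does not separate these two groups at this place, even though the entering group has more heavy atoms than the one it replaces. The other single change, hydrogen in place of chloro on an aromatic carbon, gives a 1.7-fold lower number from compound 1 to compound 3 (0.24 log units; within the scatter), which splits the earlier difference in two places into two separate changes, neither of them beyond the scatter. Nothing further is available that could explain these results.

As far as these compounds go, only fluoro and trifluoromethyl are seen at the first place and only chloro and hydrogen at the second, so it stays open whether an amine, a carboxylic acid or a methoxy group at either place would give a number beyond the scatter of these three. The amide hydrogen and the rest of the shared core are the same in all three compounds, so the compounds shown say nothing about changes there, and all of the comparisons rest on this assay alone.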